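The compounds below may be only part of what the source reports. "The series", "measured", "known", "first", "only" and "open" are said of these compounds alone.

Three compounds sharing one core were measured in a functional assay on NCI-H226 cells (Homo sapiens) for inhibition, read by MTT assay, with a stated time of 48 h, tested at 10 uM; a lower number here means less inhibition, a higher number more inhibition at the concentration tested (going by the name of the read-out). Compound 1 `COc1cc(NC(=O)Nc2cc(Nc3ccc(C(C)(C)C)cc3)ncn2)cc(OC)c1` gives 47.7%, the highest of the three numbers. Compound 2 `COc1cc(NC(=O)Nc2cc(Nc3ccc(F)c(Cl)c3)ncn2)cc(OC)c1` gives 36.7%, and compound 3 `CCc1cccc(Nc2cc(NC(=O)Nc3cc(OC)cc(OC)c3)ncn2)c1` gives 36.7%. The step of a number 11 percentage points lower from compound 1 to compound 2 (beyond the scatter) and the step of a number 11 percentage points lower from compound 1 to compound 3 (beyond the scatter) both swap the group on a nitrogen on an aromatic ring, while no change at the digits printed from compound 2 to compound 3 (within the scatter). Compound 4 `CC(C)(C)c1ccc(Nc2cc(NC(=O)Nc3c(Cl)cccc3Cl)ncn2)cc1` keeps the 4-(tert-butyl)phenyl group of compound 1 and differs elsewhere: 2,6-dichlorophenyl in place of 3,5-dimethoxyphenyl on an amide-type nitrogen. Going by the values given here, no measured step touches the group on the amide-type nitrogen, so the measured steps show only that swapping one ring for another moves the read-out modestly. The step of a number 9.7 percentage points lower from compound 1 to compound 4 (within the scatter) is therefore expected to be small, most likely a modest drop. The estimate for compound 4 is 38%, between 15% and 60%.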

Compound 4, a percentage reported as inhibition, at one concentration (the size of the read-out at that concentration, not a potency): 40%
Compound 4: the middle estimate sits 2 percentage points below what was measured; low and high end bracket the measured number.
By their numbers in this assay, from the lowest: compounds 2, 3, 4 and 1 (each within the scatter of the next, the first and the last beyond it).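

Going by these compounds alone, on the amide-type nitrogen, 2,6-dichlorophenyl in place of 3,5-dimethoxyphenyl gives in this assay a step of a number 7.7 percentage points lower from compound 1 to compound 4 (within the scatter) and thus the first reading at this position. With the 4-(tert-butyl)phenyl group held constant, this exchange of ring substituents leaves the read-out within the scatter. Nothing available accounts for this result. Still open, from the compounds shown here alone, is whether an unsubstituted phenyl, or a ring carrying an amine or a carboxylic acid, would behave alike on this nitrogen. Also open, going by these compounds, is whether 2,6-dichlorophenyl gives a similar reading alongside 3-ethylphenyl.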